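Bromophenyl Amide in Place of a Trifluoroethyl Carbamate

This account rests on a few compounds, and the source may have more. Where it says the series, first, only, none or still open, it means among the compounds named here.

Measured so far in an ADME assay on Vero cells (Chlorocebus sabaeus) for cytotoxicity, read by resazurin assay, with a stated time of 3 days; a higher number here means a weaker inhibitor, a lower number a stronger inhibitor:
compound 1 `CCN(CC)c1cc2[nH]c(C3CCCCC3)nc2cc1NC(=O)OCC(F)(F)F` — > 100 ug/mL
compound 2 `CN(C)c1cc2[nH]c(C3CCCCC3)nc2cc1NC(=O)OCC(F)(F)F` — > 100 ug/mL
compound 3 `CCOCCOC(=O)Nc1cc2nc(C3CCCCC3)[nH]c2cc1N1CCCC1` — > 100 ug/mL

Each of these values is a limit of the assay, not a number. Compound 1 therefore stands only at a limit, as do the two other values shown, all sitting at the limit of > 100 ug/mL in this assay, at which 3 of the 3 values shown sit. Among the compounds with values here, the single one-place step among them, a step that the two limits leave unreadable from compound 1 to compound 2, cannot be read because both ends are limits. Compound 4, `CCN(CC)c1cc2[nH]c(C3CCCCC3)nc2cc1NC(=O)c1cccc(Br)c1`, differs from compound 1 in one place: 3-bromophenyl in place of 2,2,2-trifluoroethoxy on a carbonyl carbon. Within the data shown here, no measured step bears on this change, so nothing points in either direction. Compound 4 is expected to stay near the same limit, estimated at 100 ug/mL (range 40 ug/mL to 250 ug/mL), a step of a number no higher from compound 1 to compound 4 (the limit leaves the size open) that is expected to be none beyond the scatter.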

Compound 4, half-maximal inhibitory concentration: > 100 ug/mL
Compound 4 gave a limit, no number; the forecaster's own chance of this, stated with the estimate: 65%; the middle value lies on the limit itself.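

In this assay, no step can be read from compound 1 to compound 4, since both values are limits and not numbers: the limit of > 100 ug/mL in this assay, at which 4 of the 4 values shown sit.

The compounds shown leave open whether 3-bromophenyl in place of 2,2,2-trifluoroethoxy changes this read-out at all.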